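The source may hold more compounds than are shown below. What is called first, only, known or untested is meant among the compounds shown, and "the series" means these compounds.

Compound 1 `Cc1cc(C)cc(SCc2ccc(/C=C/C(=O)Nc3ccccc3N)cc2)c1` carries a (3,5-dimethylphenyl)sulfanyl group and in a functional assay on A-375 cells (Homo sapiens) for inhibition, read by CCK-8 assay, with a stated time of 72 h, tested at 2 uM (a higher number here means more inhibition of growth at the concentration tested, a lower number less inhibition of growth), gives 8.78%, the second highest of the three numbers in hand. Compound 2 `Nc1ccccc1NC(=O)/C=C/c1ccc(CSc2ccc(Cl)cc2)cc1` gives 13.4% and compound 3 `Nc1ccccc1NC(=O)/C=C/c1ccc(CSc2cccc(F)c2)cc1` gives 6.75%. The steps of a number 4.6 percentage points higher from compound 1 to compound 2 (within the scatter) and a number 2 percentage points lower from compound 1 to compound 3 (within the scatter) both lie within the scatter, as does a number 6.7 percentage points lower from compound 2 to compound 3 (within the scatter). Compound 4 `CCc1ccc(SCc2ccc(/C=C/C(=O)Nc3ccccc3N)cc2)cc1` has not yet been measured in this assay. Its difference from compound 1: 4-ethylphenyl in place of 3,5-dimethylphenyl on a sulfur. Both earlier exchanges on the sulfur, to 4-chlorophenyl and to 3-fluorophenyl, stayed within the scatter, so for this exchange no step beyond the scatter is expected in this assay, a number 0.2 percentage points higher from compound 1 to compound 4 (within the scatter). Compound 4 is therefore estimated at 9%, with an expected range from 2% to 17%.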

Compound 4, percent growth inhibition at one concentration: 5.27%
Compound 4: middle estimate off by 3.7 percentage points, on the high side; the measured number falls inside the stated range.
By their numbers in this assay, from the lowest: compounds 4, 3, 1 and 2 (each within the scatter of the next).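

With the same atoms joined differently, the exchange of 3,5-dimethylphenyl for 4-ethylphenyl on the sulfur gives a number 3.5 percentage points lower from compound 1 to compound 4 (within the scatter) in this assay and so leaves the number unmoved. The steps to compound 4 from the other two compounds also stay small, with a number 1.5 percentage points lower from compound 3 to compound 4 (within the scatter) for the exchange from 3-fluorophenyl and a number 8.1 percentage points lower from compound 2 to compound 4 (within the scatter) for ethyl in place of chloro on an aromatic carbon. No accompanying data bear on these numbers.

Open, from the compounds shown here alone, is whether an amine or a carboxylic acid on this aromatic ring, or a benzyl group on the sulfur, would give a step beyond the scatter.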